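Swapping a Hydroxyphenyl for a Sulfonamide on the Triazole

The source may report more compounds than this note shows. Statements on the series, on what has been measured and on what is new or still open speak of the compounds shown alone.

Measured compounds in a functional assay on HCT-116 cells (Homo sapiens) for antiproliferative activity, read by MTT assay, with a stated time of 72 h; a lower number here means a stronger inhibitor, a higher number a weaker inhibitor:
- Compound 1, `O=C1O[C@H]([C@@H](O)Cn2cc(-c3ccc(Br)cc3)nn2)C(OCc2ccccc2)=C1OCc1ccccc1`, gives 9420 nM.
- Compound 2, `O=C1O[C@H]([C@@H](O)Cn2cc(-c3cccc(O)c3)nn2)C(OCc2ccccc2)=C1OCc1ccccc1`, gives 42900 nM.
- Compound 3, `COc1ccc(-c2cn(C/C=C3\OC(=O)C(OCc4ccccc4)=C3OCc3ccccc3)nn2)cc1`, reaches only > 100000 nM, which is a limit of this assay rather than a number.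

Among the two compounds with numbers, compound 2 stands highest, that is, it is the weaker inhibitor; its nearest neighbour is compound 1, and the step of a 4.6-fold higher number from compound 1 to compound 2 (0.66 log units; beyond the scatter) is modest but beyond the scatter. Compound 3 sits at the limit noted in the limit of > 100000 nM in this assay, at which 1 of the 3 values shown sits.

Compound 4, `Cc1ccc(S(=O)(=O)NCc2cn(C[C@H](O)[C@H]3OC(=O)C(OCc4ccccc4)=C3OCc3ccccc3)nn2)cc1`, differs from compound 2 by (((4-methylphenyl)sulfonyl)amino)methyl in place of 3-hydroxyphenyl on an aromatic carbon. Within the data shown here, no measured step involves a sulfonamide, so the only guide is that changing the aromatic group in this position moved the number by the size of a 4.6-fold higher number from compound 1 to compound 2 (0.66 log units; beyond the scatter). A step of similar size, in either direction, is therefore expected, and the number for compound 4 is estimated at 50000 nM, within 15000 nM to 150000 nM, corresponding to an expected step of a 1.2-fold higher number from compound 2 to compound 4 (0.07 log units; within the scatter).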

Compound 4, half-maximal inhibitory concentration: 13100 nM
Compound 4: middle estimate off by 3.8-fold (0.58 log units), on the high side; measured number below the stated range.
By their numbers in this assay, from the lowest: compounds 1 and 4 (each within the scatter of the next); then compound 2. At a limit, above all of these: compound 3.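

Replacing 3-hydroxyphenyl with the larger (((4-methylphenyl)sulfonyl)amino)methyl group brings a 3.3-fold lower number from compound 2 to compound 4 (0.52 log units; beyond the scatter), so this aromatic carbon can carry more than a phenyl ring attached directly without the number rising. Set against the 4-bromophenyl group, the same new group shows a 1.4-fold higher number from compound 1 to compound 4 (0.14 log units; within the scatter), so these two quite different groups cannot be told apart by this read-out. Nothing measured here explains why the 3-hydroxyphenyl compound gives the higher number.

On these data alone, it remains open how far this tolerance reaches, for instance whether an amide in place of the sulfonamide, or a longer chain in place of the methyl link, would keep the number level. It is also unclear which part of the new group matters, and a simple amine or a carboxylic acid on this carbon could help to show that.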